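Chain extension on the benzyl-bearing core: notes before compound 4

The source may hold more compounds than are shown below. What is called first, only, known or untested is meant among the compounds shown, and "the series" means these compounds.

Compound 3 `CCCc1cn(Cc2ccccc2)nn1` is taken as the starting point. Within the data shown here, in an assay on isolated protein for inhibition of Aromatase (Homo sapiens), read by fluorescence and colorimetric assay, with a stated time of 30 min (on this read-out lower numbers stand for stronger inhibition and higher numbers for weaker inhibition), compound 3 gives 12600 nM, which stands second highest among the three numbers measured so far. Its nearest neighbour is compound 1 `CCCc1cn(C(c2ccccc2)c2ccccc2)nn1`, which in this assay gives 11000 nM; the step of a 1.1-fold higher number from compound 1 to compound 3 (0.06 log units; within the scatter) stays within the scatter. Furthest from it is compound 2 `CCCCCCc1cn(C(c2ccccc2)c2ccccc2)nn1`, which in this assay gives 14800 nM, still within the scatter of compound 3. Among the measured compounds shown here, all three numbers sit close together, and no compound can be called stronger or weaker than another on these data.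

Compound 4 `CCCCCCc1cn(Cc2ccccc2)nn1` is not yet measured. It differs from compound 3 by propyl in place of hydrogen on a saturated chain carbon, three bonds along the chain from an aromatic carbon. The same change has one measured precedent in the series: a 1.3-fold higher number from compound 1 to compound 2 (0.13 log units; within the scatter), a step that did not exceed the scatter. For the measured compounds named here, no other measured step bears on this change. Going by the values given here, on that basis no step beyond the scatter is expected in this assay for compound 4, with at most a slight drift toward a higher number, as the one precedent showed. The step of a 1.2-fold higher number from compound 3 to compound 4 (0.08 log units; within the scatter) is therefore expected to be small. Compound 4 is estimated at 15000 nM, with a range from 8000 nM to 28000 nM.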

Compound 4, half-maximal inhibitory concentration: 7470 nM
Compound 4: the middle estimate sits 2.0-fold (0.30 log units) above what was measured, and the stated range ends above it.
By their numbers in this assay, from the lowest: compounds 4, 1, 3 and 2 (each within the scatter of the next).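

Propyl in place of hydrogen on this saturated chain carbon can now be read on a second core in this assay, and a 1.7-fold lower number from compound 3 to compound 4 (0.23 log units; within the scatter) stays inside the scatter as the first reading did, with the two readings pointing opposite ways, so the change has no established direction: the same change on two cores in this assay, a 1.3-fold higher number (0.13 log units; within the scatter) from compound 1 to compound 2 and a 1.7-fold lower number (0.23 log units; within the scatter) from compound 3 to compound 4, 2.3-fold (0.36 log units) apart, within the scatter of two such steps

Hydrogen in place of phenyl on the chain carbon bound to an aromatic carbon and an aromatic nitrogen also gains a second reading, a 2.0-fold lower number from compound 2 to compound 4 (0.30 log units; within the scatter), and the two readings do not separate: the same change on two cores in this assay, a 1.1-fold higher number (0.06 log units; within the scatter) from compound 1 to compound 3 and a 2.0-fold lower number (0.30 log units; within the scatter) from compound 2 to compound 4, 2.3-fold (0.36 log units) apart, within the scatter of two such steps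

Taken together, the four compounds form a closed set of single changes in which neither swapping propyl for hexyl nor removing the phenyl moves the number in this assay beyond the scatter.

As far as these compounds go, it remains open whether this position responds to anything other than a plain alkyl chain: a longer chain, or an amine or a carboxylic acid carried on the chain, might still shift the number beyond the scatter. With all four values in one narrow band, whether any change on the shared core can give a clearly lower number in this assay also stays unanswered.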